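This account rests on a few compounds, and the source may have more. Where it says the series, first, only, none or still open, it means among the compounds named here.

Measured so far:
compound 1 `Cc1cc(-c2nc3sc(C)cn3c2/C=N/NC(=N)N)c(C)s1` — 12000 nM
compound 2 `N=C(N)N/N=C/c1c(-c2cc(Cl)sc2Cl)nc2n1CCS2` — 10500 nM
compound 3 `Cc1cc(-c2nc3sccn3c2/C=N/NC(=N)N)c(C)s1` — 17400 nM

In a functional assay on cells (Cancer cell lines, Homo sapiens) for inhibition (a higher number here means a weaker inhibitor of growth, a lower number a stronger inhibitor of growth), compound 2 gives 10500 nM, the lowest of the three numbers, but its nearest neighbour is compound 1 with 12000 nM and the furthest is compound 3 with 17400 nM, and both gaps lie within the scatter, so no order among the three can be claimed. Within the data shown here, the only single-point step among them, a 1.5-fold higher number from compound 1 to compound 3 (0.16 log units; within the scatter), is itself within the scatter.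

Compound 4 `N=C(N)N/N=C/c1c(-c2cccs2)nc2n1CCS2` is not yet measured. It differs from compound 2 by thiophen-2-yl in place of 2,5-dichlorothiophen-3-yl on an aromatic carbon. Among the measured compounds shown here, no measured step touches this part of the molecule: the one available step concerns a methyl on the other ring, so it bears only indirectly, showing that a small change there left this assay unmoved. With three compounds sitting together and nothing to suggest a shift in either direction, a step beyond the scatter is not expected.

Compound 4 is therefore expected to give about 15000 nM in this assay, within a range of 6000 nM to 40000 nM. The step this implies is expected to be a 1.4-fold higher number from compound 2 to compound 4 (0.15 log units; within the scatter), staying within the scatter.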

Compound 4, concentration for 50% growth inhibition: 39800 nM
The estimate for compound 4 lay 2.7-fold (0.42 log units) below the measured number; low and high end bracket the measured number.
By their numbers in this assay, from the lowest: compounds 2, 1 and 3 (each within the scatter of the next); then compound 4.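

In this assay, this aromatic carbon is the first place among the compounds shown where a single change moves the number beyond the scatter: a 3.8-fold higher number from compound 2 to compound 4 (0.58 log units; beyond the scatter), a modest step towards weaker inhibition of growth. Among these compounds, the only earlier step, the methyl change a 1.5-fold higher number from compound 1 to compound 3 (0.16 log units; within the scatter), stayed within the scatter, so the group at this position matters to growth inhibition in a way that step could not show. The change is a double one, since thiophen-2-yl both lacks the two chlorine atoms of 2,5-dichlorothiophen-3-yl and joins the core through a different ring carbon, and nothing available explains why the number moves.

The compounds shown do not separate these two parts of the change, so it remains open whether the loss of chlorine or the different point of attachment accounts for the step. Also open, going by these compounds, is how an unsubstituted thiophen-3-yl, a thiophene with a single chlorine, or a different group such as phenyl or an amine on this carbon would compare with compound 2 and compound 4.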